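The source may report more compounds than this note shows. Statements on the series, on what has been measured and on what is new or still open speak of the compounds shown alone.

Measured in a physicochemical assay for solubility, read by chemiluminescence, measured as kinetic solubility; a higher number here means a more soluble compound, a lower number a less soluble compound:
- Compound 1 `O=C(C1CCCN1)N1CCC2(CCN(c3nccc(NCc4ccc(Cl)cc4Cl)n3)CC2)C1` gives 79 ug/mL
- Compound 2 `O=C([C@H]1CCCN1)N1CCC2(CCN(c3nccc(NCc4ccc(Cl)cc4Cl)n3)CC2)C1` gives 180 ug/mL
- Compound 3 `O=C([C@@H]1CCCCN1)N1CCC2(CCN(c3nccc(NCc4ccc(Cl)cc4Cl)n3)CC2)C1` gives 170 ug/mL

Compound 2 sits in the upper pair of these values, with a 1.1-fold lower number from compound 2 to compound 3 (0.02 log units; within the scatter), and the remaining gap is a 2.3-fold higher number from compound 1 to compound 2 (0.36 log units; beyond the scatter).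

Compound 4 `O=C(c1ccccn1)N1CCC2(CCN(c3nccc(NCc4ccc(Cl)cc4Cl)n3)CC2)C1` carries pyridin-2-yl in place of pyrrolidin-2-yl on a carbonyl carbon. The closest measured changes at this place put piperidin-2-yl there instead, giving a 2.2-fold higher number from compound 1 to compound 3 (0.33 log units; beyond the scatter) and the step already noted for compound 3. Neither places an aromatic ring on the carbonyl carbon, so they only loosely guide the size. A fall in this assay beyond the scatter and larger than these steps is expected, with an estimated 4.5-fold lower number from compound 2 to compound 4 (0.65 log units; beyond the scatter). For compound 4 the expected value is 40 ug/mL, within an estimated range of 10 ug/mL to 130 ug/mL.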

Compound 4, solubility: 17 ug/mL
Compound 4: middle estimate off by 2.4-fold (0.37 log units), on the high side; low and high end bracket the measured number.
By their numbers in this assay, from the lowest: compound 4; then compound 1; then compounds 3 and 2 (each within the scatter of the next).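

Pyridin-2-yl is the only aromatic ring on this carbonyl carbon among the compounds shown, and in this assay compound 4 stands lowest, with steps well beyond those among the saturated rings (an 11-fold lower number from compound 2 to compound 4 (1.02 log units; beyond the scatter); a 10-fold lower number from compound 3 to compound 4 (1.00 log units; beyond the scatter)). Measured from compound 1, the same change reads smaller (a 4.6-fold lower number from compound 1 to compound 4 (0.67 log units; beyond the scatter)), and the two starting points differ only in the following: the fact that one of compounds 1 and 2 is drawn with a defined configuration and the other without, at the place where they differ.

From the compounds shown here alone, whether the fall tracks aromaticity or the hydrogen-bond donor that leaves with pyrrolidin-2-yl remains open. A phenyl ring or an aminopyridine at this position would separate the two.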